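Swapping 4-cyanophenyl on the sulfonamide nitrogen

The source may hold more compounds than are shown below. What is called first, only, known or untested is meant among the compounds shown, and "the series" means these compounds.

In an ADME assay on microsomes from liver (Homo sapiens) for metabolic stability, read by LC-MS, with a stated time of 30 min (on this read-out higher numbers stand for a longer-lived compound and lower numbers for a shorter-lived compound), compound 2 (`CC(C)CN(c1ccc(C#N)cc1)S(=O)(=O)c1ccc2c(c1)C(O)CC(C1CCOCC1)O2`) gives 0.8 h and stands lowest of the two numbers, while compound 1 (`CCc1ccc(N(CC(C)C)S(=O)(=O)c2ccc3c(c2)C(O)CC(C2CCOCC2)O3)cc1`) gives 3.7 h on the same read-out. Compound 3 (`CC(C)CN(c1cc2ccccc2s1)S(=O)(=O)c1ccc2c(c1)C(O)CC(C1CCOCC1)O2`) differs from compound 2 by 1-benzothiophen-2-yl in place of 4-cyanophenyl on a sulfonamide nitrogen. Within the data shown here, only one measured step bears on this group (a 4.6-fold lower number from compound 1 to compound 2 (0.67 log units; beyond the scatter)), and it changed a smaller part of it, so it is a loose guide. A small rise, within the scatter, is expected (a 1.9-fold higher number from compound 2 to compound 3 (0.27 log units; within the scatter)). In this assay compound 3 is expected at 1.5 h (estimated range 0.5 h to 4.5 h).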

Compound 3, half-life in the Homo sapiens assay: 25.2 h
Compound 3: middle estimate off by 17-fold (1.23 log units), on the low side; measured number above the stated range.
By their numbers in the Homo sapiens assay, from the lowest: compound 2; then compound 1; then compound 3.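

In the Homo sapiens assay, the group on the sulfonamide nitrogen moves the half-life much further than the change on the phenyl ring alone had shown: replacing the whole aryl group gives a 32-fold higher number from compound 2 to compound 3 (1.50 log units; beyond the scatter), and a 6.8-fold higher number from compound 1 to compound 3 (0.83 log units; beyond the scatter). In a physicochemical assay for lipophilicity, at pH 7.4 (a lower number here means a more polar compound, a higher number a more lipophilic compound), compound 2 gives 3.07 and compound 3 gives 3.92. The longer half-life came with a more lipophilic compound, not a more polar one: the measured distribution coefficient of compound 2, 3.07, and of compound 3, 3.92, a number 0.85 log units higher (beyond the scatter)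

The compounds shown leave open whether the gain belongs to the sulfur or to the second aromatic ring of 1-benzothiophen-2-yl. A thiophen-2-yl or 1-benzofuran-2-yl group on the same nitrogen would separate the two.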